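Swapping sulfo for a tetrazole in a permeability test

The source may hold more compounds than are shown below. What is called first, only, known or untested is meant among the compounds shown, and "the series" means these compounds.

In an ADME assay on MDCKII-LE cells (Canis lupus familiaris) for permeability (a lower number here means that the compound crosses the layer more slowly, a higher number that the compound crosses the layer faster), compound 1 `Cc1ccc(NC(=O)[C@H](CC2CCCC2)n2cnc(C(F)(F)F)c2)nc1` gives 17.4 10^-6 cm/s, while compound 2 `O=C(Nc1ccc(S(=O)(=O)O)cn1)[C@H](CC1CCCC1)n1cnc(C(F)(F)F)c1` gives 0.7 10^-6 cm/s, the lower of the two numbers. Compound 3 `O=C(Nc1ccc(-c2nnn[nH]2)cn1)[C@H](CC1CCCC1)n1cnc(C(F)(F)F)c1` carries 1H-tetrazol-5-yl in place of sulfo on an aromatic carbon. Among the compounds with values here, only one measured step bears on this place: a 25-fold lower number from compound 1 to compound 2 (1.40 log units; beyond the scatter), which is large and came with sulfo replacing methyl. Within the data shown here, no measured compound carries 1H-tetrazol-5-yl, so the guide is weak, and only a small rise in this assay is expected. The expected step is a 1.9-fold higher number from compound 2 to compound 3 (0.27 log units; within the scatter). For compound 3, the estimate is 1.3 10^-6 cm/s, within a range of 0.4 10^-6 cm/s to 4.5 10^-6 cm/s.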

Compound 3, apparent permeability: 0.6 10^-6 cm/s
For compound 3 the middle estimate is 2.2-fold (0.34 log units) above the measured one, within the range that was stated.
By their numbers in this assay, from the lowest: compounds 3 and 2 (each within the scatter of the next); then compound 1.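

In this assay, 1H-tetrazol-5-yl and sulfo on this aromatic carbon read alike (a 1.2-fold lower number from compound 2 to compound 3 (0.07 log units; within the scatter)). The large gap from methyl therefore does not belong to sulfo alone, since the tetrazole shows it too (a 29-fold lower number from compound 1 to compound 3 (1.46 log units; beyond the scatter)). Nothing shown gives a measured property that would account for this. Still open, going by these compounds, is whether a carboxylic acid, an amine or a methyl ester at this place would read like these two groups or like methyl. Whether a longer chain holding the tetrazole away from the ring would change the number is also unanswered.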